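Cyclohexyl to Cyclobutyl on Two Related Cores

A few compounds are considered here, and "the series" means these few. Any claim that something is new, unique, unknown or untested is made for them only; others in the source may bear on it.

Compound 1, `C[N+]1(CC2CCCCC2)CCc2c(sc(NC(=O)Nc3ccc(Cl)cc3)c2C(N)=O)C1`, gives 100 nM in a functional assay (strain AB) with Danio rerio as the target, read by microscopy, with a stated time of 1 h; a lower number here means that less compound is needed, a higher number that more compound is needed for the effect.
Compound 2, `C[N+]1(CC2CCC2)CCc2c(sc(NC(=O)Nc3ccc(Cl)cc3)c2C(N)=O)C1`, gives 210 nM in this assay.
Compound 3, `NC(=O)c1c(NC(=O)Nc2ccc(Cl)cc2)sc2c1CCN(CC1CCCCC1)C2`, gives 1890 nM in this assay.

Compound 1 and compound 2 differ in one place, (cyclobutyl in place of cyclohexyl on a saturated chain carbon bound to an amine nitrogen in a ring), and that change brought a 2.1-fold higher number from compound 1 to compound 2 (0.32 log units; beyond the scatter). Compound 3 shares the urea and amide part of compound 1 but its core differs; how the two cores differ is not broken down here, and compound 3 shows the highest number of the three.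

Compound 4, `NC(=O)c1c(NC(=O)Nc2ccc(Cl)cc2)sc2c1CCN(CC1CCC1)C2`, is not yet measured. It differs from compound 3 in one place, (cyclobutyl in place of cyclohexyl on a saturated chain carbon bound to an amine nitrogen in a ring), the same change that led from compound 1 to compound 2, made at the same place. A step of about the same size is expected here, a 2.1-fold higher number from compound 3 to compound 4 (0.33 log units; beyond the scatter), because compound 1 to compound 2 gave a 2.1-fold higher number from compound 1 to compound 2 (0.32 log units; beyond the scatter), with wider uncertainty since the core of compound 3 is a different one. Compound 4 is therefore estimated at 4000 nM in this assay, within 1900 nM to 9000 nM.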

Compound 4, half-maximal effective concentration: 1360 nM
Beside the measured number, compound 4's estimate is 2.9-fold (0.47 log units) above it; the measured number lies below the stated range.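

In this assay, putting cyclobutyl in place of cyclohexyl gave a 1.4-fold lower number from compound 3 to compound 4 (0.14 log units; within the scatter), so on this core the two groups cannot be told apart. Set beside the earlier step, the same change did not carry over from one core to the other with the same size: the same change on two cores in this assay, a 2.1-fold higher number (0.32 log units; beyond the scatter) from compound 1 to compound 2 and a 1.4-fold lower number (0.14 log units; within the scatter) from compound 3 to compound 4, 2.9-fold (0.47 log units) apart, beyond the scatter of two such steps With only one pair on each core, this shows that the step on one core was a poor guide to the step on the other, but it does not show why the two cores differ or what the change would do on any further core.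

The compounds shown leave open how a cyclopentyl group or a longer chain in the same place would behave on each core. They also leave open whether the gap between the two steps would persist with a group other than the 4-chlorophenyl urea.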